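A few compounds are considered here, and "the series" means these few. Any claim that something is new, unique, unknown or untested is made for them only; others in the source may bear on it.

Within the data shown here, compound 3 `COc1cc(/C=C/C(=O)/C=C(O)/C=C/c2ccc(O[C@]3(C)C=C[C@@H]([C@@H](C)CC(=O)C=C(C)C)C[C@@H]3O)c(OC)c2)ccc1O` gives 19400 nM in a functional assay on MDA-MB-231 cells (Homo sapiens) for cytotoxicity, read by crystal violet staining, with a stated time of 72 h (a higher number here means a weaker inhibitor, a lower number a stronger inhibitor), the lowest number of the three measured so far, though its gap to compound 1 is within the scatter. Compound 1 `COc1cc(/C=C/C(=O)/C=C(O)/C=C/c2ccc(O[C@H]3C=C(C)[C@@H](O)C[C@@H]3[C@@H](C)CCC=C(C)C)c(OC)c2)ccc1O` gives 27300 nM in this assay. Compound 2 `COc1cc(/C=C/C(=O)/C=C(O)/C=C/c2ccc(O[C@]3(C)C=C[C@@H]([C@@H](C)CCC=C(C)C)C[C@@H]3O)c(OC)c2)ccc1O` gives 84100 nM in this assay. Among the measured compounds shown here, the only single-point step among the measured compounds is a 4.3-fold lower number from compound 2 to compound 3 (0.64 log units; beyond the scatter), which concerns a different part of the molecule from the aromatic ring at issue below.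

Compound 4 `COc1cc(/C=C/C(=O)/C=C(O)/C=C/c2ccc(O[C@]3(C)C=C[C@@H]([C@@H](C)CC(=O)C=C(C)C)C[C@@H]3O)cc2)ccc1O` differs from compound 3 by hydrogen in place of methoxy on an aromatic carbon. For the measured compounds named here, none of the measured compounds differs from another by the presence or absence of a methoxy on an aromatic carbon, so no measured step bears directly on this change. Going by the values given here, the one step recorded, a 4.3-fold lower number from compound 2 to compound 3 (0.64 log units; beyond the scatter), was modest and lies elsewhere in the structure, and it gives no guidance on the present change. With nothing to indicate a shift in either direction, no step beyond the scatter is expected in this assay for compound 4, and the working assumption is a number close to that of compound 3. The estimate for compound 4 is 22000 nM, with a range from 9000 nM to 55000 nM, corresponding to an expected step of a 1.1-fold higher number from compound 3 to compound 4 (0.05 log units; within the scatter).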

Compound 4, half-maximal inhibitory concentration: 15900 nM
Compound 4: the middle estimate sits 1.4-fold (0.14 log units) above what was measured; the measured number falls inside the stated range.
By their numbers in this assay, from the lowest: compounds 4, 3 and 1 (each within the scatter of the next); then compound 2.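

In this assay, among these compounds, taking away the methoxy on this aromatic carbon, ortho to a large group and meta to a large group, gives a 1.2-fold lower number from compound 3 to compound 4 (0.09 log units; within the scatter), the first reading of this change. With the (2-methylprop-1-en-1-yl)carbonyl chain in place, compound 3 and compound 4 therefore cannot be told apart: this methoxy can be replaced by hydrogen without a step beyond the scatter, whereas the chain change in a 4.3-fold lower number from compound 2 to compound 3 (0.64 log units; beyond the scatter) does go beyond it. No measurement shown here accounts for either the size of this step or how the compounds act on the cells.

Going by these compounds, it remains open whether hydrogen and methoxy would also read alike on the background of compound 2, which carries the 3-methylbut-2-en-1-yl chain, and whether the methoxy on the other aromatic ring can be treated in the same way. Also open, on these data alone, is how this aromatic carbon would respond to groups other than hydrogen and methoxy, such as an ethoxy, a fluorine, an amine or a carboxylic acid, any of which could show whether this position tolerates change more generally.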